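This account rests on a few compounds, and the source may have more. Where it says the series, first, only, none or still open, it means among the compounds named here.

Measured so far:
- compound 1, `CCOC(=O)C1=C(S[C@@H]2CN[C@H](C(=O)Nc3cccc(C(=O)OCC)c3)C2)[C@H](C)[C@@H]2[C@@H]([C@@H](C)OC(=O)CC)C(=O)N12`: 22% in an ADME assay on a cell-free system (plasma, Homo sapiens) for metabolic stability, read by LC-MS, with a stated time of 60 min, at 37 degrees C, tested at 50 uM; a higher number here means that more of the compound is left, a lower number that less of the compound is left
- compound 2, `CCOC(=O)c1cccc(NC(=O)[C@@H]2C[C@H](SC3=C(C(=O)O)N4C(=O)[C@H]([C@@H](C)O)[C@H]4[C@H]3C)CN2)c1`: "not determined" (no result reported) in this assay

Among the compounds with values here, compound 2 stands nowhere on the numbers: in this assay it has no single value, so no step from it can be sized in either direction. Compound 3, `CCOC(=O)C1=C(S[C@@H]2CN[C@H](C(=O)Nc3cccc(C(=O)OCC)c3)C2)[C@H](C)[C@@H]2[C@@H]([C@@H](C)O)C(=O)N12`, differs from compound 2 by ethyl in place of hydrogen on an oxygen next to a carbonyl group. Within the data shown here, with no step between measured compounds, the expectation for compound 3 rests on compound 1 alone, which also carries ethoxycarbonyl groups and gives 22%. Compound 3 is therefore expected to land in a similar region, perhaps somewhat higher, since it shares fewer of the features of compound 1, but the direction relative to compound 2 cannot be stated beyond the scatter. The estimate for compound 3 in this assay is 35%, expected to fall between 15% and 60%.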

Compound 3, percent of the compound remaining: 5%
Estimate against measurement, compound 3: 30 percentage points above, outside the stated range (below it).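

In this assay the oxygen on a saturated carbon proves to be a position that counts: the change to hydrogen in place of propanoyl gives a number a number 17 percentage points lower from compound 1 to compound 3 (beyond the scatter) and so leaves less of the compound. Within the data shown here, this is the first readable step, and it shows that the propanoyl group on this oxygen is not neutral for the read-out, with the rest of the structure unchanged. Nothing at hand bears on the reason for this step.

From the compounds shown here alone, the step from compound 2 to compound 3 cannot be read, as compound 2 has no number, so the effect of ethyl in place of hydrogen on an oxygen next to a carbonyl group stays open. Also open, going by these compounds, is how acetyl, a longer chain such as butanoyl, or a methyl ether on the saturated-carbon oxygen would compare.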